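A few compounds are considered here, and "the series" means these few. Any claim that something is new, unique, unknown or untested is made for them only; others in the source may bear on it.

Working notes on a short peptide-aldehyde series. Compound 1 `CC(=O)N[C@@H](CC(C)C)C(=O)N[C@@H](CC(C)C)C(=O)N[C@H](C=O)CCCNC(N)=O` gives 5200 nM in an assay on isolated protein for inhibition of serine protease 1 (Homo sapiens); on this read-out higher numbers stand for weaker inhibition and lower numbers for stronger inhibition. Compound 2 `CC(C)C[C@H](NC(=O)OCc1ccccc1)C(=O)N[C@@H](CC(C)C)C(=O)N[C@H](C=O)CCCN=C(N)N` gives 164000 nM in this assay, the highest number of the two; the gap to compound 1 lies beyond the scatter. Compound 3 `CC(C)C[C@H](NC(=O)OCc1ccccc1)C(=O)N[C@H](C(=O)N[C@H](C=O)CCCN=C(N)N)C(C)C` is not yet measured and differs from compound 2 by isopropyl in place of isobutyl on a saturated chain carbon bound to an amide-type nitrogen and a carbonyl carbon. Among the measured compounds shown here, no step between measured compounds isolates this change, so the expected step of a 1.2-fold higher number from compound 2 to compound 3 (0.09 log units; within the scatter) is put at none beyond the scatter, if anything a slight rise. For compound 3 the estimate in this assay is 200000 nM, range 60000 nM to 700000 nM.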

Compound 3, half-maximal inhibitory concentration: 81400 nM
Compound 3: middle estimate off by 2.5-fold (0.39 log units), on the high side, within the range that was stated.
By their numbers in this assay, from the lowest: compound 1; then compounds 3 and 2 (each within the scatter of the next).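

Isopropyl in place of isobutyl on a saturated chain carbon bound to an amide-type nitrogen and a carbonyl carbon gives a 2.0-fold lower number from compound 2 to compound 3 (0.30 log units; within the scatter) in this assay. Among the compounds shown here, this is the only step read at this position, and it shows that the two groups cannot be told apart on this read-out. Nothing on hand offers an explanation for the result.

From the compounds shown here alone, whether a carboxylic acid, an amine or a longer chain at this position would give a step beyond the scatter stays open. Compound 1 differs from compound 2 in more than one place, so its gap cannot be assigned to any single change.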